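Adding a methyl to the ring nitrogen of compound 2

The source may report more compounds than this note shows. Statements on the series, on what has been measured and on what is new or still open speak of the compounds shown alone.

compound 1, `CN(Cc1ccc(OCCCN)cc1)c1nc2ccc(Oc3ccc(O)cc3)cc2s1`: 165000 nM
compound 2, `N=C(N)NCCCOc1ccc(CNc2nc3ccc(Oc4ccc(O)cc4)cc3s2)cc1`: 319000 nM

Of the compounds shown here, two have been measured in an assay on cells for inhibition of Voltage-dependent T-type calcium channel subunit alpha-1H (Homo sapiens), read by FLIPR and calcium flux, with stated times of 600 s and 300 s; a lower number here means a stronger inhibitor, a higher number a weaker inhibitor. Compound 1 `CN(Cc1ccc(OCCCN)cc1)c1nc2ccc(Oc3ccc(O)cc3)cc2s1` gives 165000 nM. Compound 2 `N=C(N)NCCCOc1ccc(CNc2nc3ccc(Oc4ccc(O)cc4)cc3s2)cc1` gives 319000 nM, the higher of the two numbers, though its gap to compound 1 is within the scatter, so the two cannot be ordered. Compound 3 `CN(Cc1ccc(OCCCNC(=N)N)cc1)c1nc2ccc(Oc3ccc(O)cc3)cc2s1` has not been measured. It differs from compound 2 by methyl in place of hydrogen on a nitrogen on an aromatic ring. Within the data shown here, no step between measured compounds matches this change, so there is no measured guide for its size. Compound 1 carries the same methyl on the same nitrogen and differs from compound 2 elsewhere as well, and its number lies within the scatter of compound 2. On this basis the step of a 1.3-fold lower number from compound 2 to compound 3 (0.11 log units; within the scatter) is expected to be none beyond the scatter. Compound 3 is expected to give about 250000 nM, between 100000 nM and 700000 nM.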

Compound 3, half-maximal inhibitory concentration: 332000 nM
For compound 3 the middle estimate is 1.3-fold (0.12 log units) below the measured one; the measured number falls inside the stated range.
By their numbers in this assay, from the lowest: compounds 1, 2 and 3 (each within the scatter of the next).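

In this assay methyl in place of hydrogen on a nitrogen on an aromatic ring makes no readable difference, with a 1.0-fold higher number from compound 2 to compound 3 (0.02 log units; within the scatter), so at this position the methyl leaves the number where it stood. Among these compounds, with that methyl kept, the group of 3 heavy atoms (1 carbon, 2 nitrogen; no ring) in place of a hydrogen atom on an amine nitrogen also stays within the scatter, with a 2.0-fold higher number from compound 1 to compound 3 (0.30 log units; within the scatter), which gives the first measured single change at the chain end. Nothing measured here bears on why neither change moves the number.

Going by these compounds, whether a larger group on the same nitrogen, such as ethyl or acetyl, would move the number beyond the scatter remains open. So does the effect of a longer chain or a carboxylic acid at the chain end.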